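The source may hold more compounds than are shown below. What is called first, only, known or untested is meant among the compounds shown, and "the series" means these compounds.

Compound 3 `Cc1cccc(-c2ccc(CCC(=O)N3CCCC3)cc2)c1` carries a 3-methylphenyl on the distal ring of a biphenyl propanoyl pyrrolidine. In an assay on HEK293 cells for inhibition of N-acylethanolamine-hydrolyzing acid amidase (Rattus norvegicus), read by LC-MS, with a stated time of 30 min (on this read-out lower numbers stand for stronger inhibition and higher numbers for weaker inhibition), compound 3 gives 16500 nM, the higher of the two numbers that this assay has produced so far. Its nearest neighbour, compound 1 `O=C(CCCCCCc1cccc(F)c1)N1CCCC1`, gives 7300 nM, and the gap between the two lies beyond the usual scatter of repeated measurements. Compound 2 `O=C(CCCCCCc1ccccc1Cl)N1CCCC1` gives > 100000 nM, which is a limit of the assay rather than a number, and it therefore sits at the limit of > 100000 nM in this assay, at which 1 of the 3 values shown sits.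

Compound 4 `O=C(CCc1ccc(-c2ccccc2Cl)cc1)N1CCCC1` is the next structure to be measured. It differs from compound 3 by 2-chlorophenyl in place of 3-methylphenyl on an aromatic carbon, in words 2-chlorophenyl in place of 3-methylphenyl on an aromatic carbon. Going by the values given here, no measured pair isolates exactly this exchange, so the expected step from compound 3 to compound 4 is set at a 2.1-fold higher number from compound 3 to compound 4 (0.33 log units; beyond the scatter), in the direction of weaker inhibition and somewhat beyond the scatter. On that basis compound 4 is estimated at about 35000 nM, with a plausible range from 9000 nM to 100000 nM.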

Compound 4, half-maximal inhibitory concentration: > 100000 nM
Compound 4 ended at the assay's limit; the forecaster's own chance of this, stated with the estimate: 35%; middle value at least 2.8-fold (0.45 log units) from the limit.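

In this assay, 2-chlorophenyl in place of 3-methylphenyl on this aromatic carbon gives an at least 6.0-fold higher number from compound 3 to compound 4 (0.78 log units; beyond the scatter), so the position does not treat the two groups alike, even though their heavy-atom, donor and acceptor counts match. Compound 4 gives > 100000 nM, which is a limit of the assay and not a number. The full size of the step therefore stays unknown, and the series has now reached that limit more than once: the limit of > 100000 nM in this assay, at which 2 of the 4 values shown sit.

The compounds shown do not separate the chlorine from its place on the ring: a 3-chlorophenyl or a 2-methylphenyl on this carbon would do that. Also open, going by these compounds, is how an amine or a carboxylic acid on this ring would read in the same assay.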